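The compounds below may be only part of what the source reports. "The series", "measured", "known", "first", "only" and "open" are said of these compounds alone.

Measured in a functional assay, read by spectrophotometry, tested at 100 uM; a lower number here means a stronger inhibitor, a higher number a weaker inhibitor:
- Compound 1 `O=C(/C=C/c1ccccc1)c1cccc(NC(=O)c2cc(-c3ccncc3)n[nH]2)c1`: 71500 nM
- Compound 2 `O=C(/C=C/c1ccc(Cl)cc1)c1cccc(NC(=O)c2cc(-c3ccncc3)n[nH]2)c1`: 78900 nM

Compound 2, at 78900 nM, cannot be told apart from compound 1, since the gap between them lies within the scatter of repeated measurements. Compound 3 `COc1ccc(/C=C/C(=O)c2cccc(NC(=O)c3cc(-c4ccncc4)n[nH]3)c2)cc1` has not yet been measured. It carries methoxy in place of chloro on an aromatic carbon, para to a large group: methoxy in place of chloro on an aromatic carbon.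

Among the measured compounds shown here, only one measured step bears on this change: a 1.1-fold higher number from compound 1 to compound 2 (0.04 log units; within the scatter), with chloro in place of hydrogen on an aromatic carbon. For the measured compounds named here, that step stayed within the scatter, but no measured compound carries methoxy, so the evidence is thin. No step beyond the scatter is therefore expected in this assay, and the estimated change is a 1.1-fold lower number from compound 2 to compound 3 (0.04 log units; within the scatter). For compound 3 the expected value is 72000 nM, with an estimated range of 35000 nM to 100000 nM.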

Compound 3, half-maximal inhibitory concentration: 54600 nM
Compound 3: the middle estimate sits 1.3-fold (0.12 log units) above what was measured, and the stated range covers the measured number.
By their numbers in this assay, from the lowest: compounds 3, 1 and 2 (each within the scatter of the next).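

In this assay, methoxy at this position, para to a large group, gives a 1.4-fold lower number from compound 2 to compound 3 (0.16 log units; within the scatter) and a 1.3-fold lower number from compound 1 to compound 3 (0.12 log units; within the scatter) and so adds a third group to the earlier comparison of chloro with hydrogen. Both steps stay within the scatter, so hydrogen, chloro and methoxy on this aromatic carbon cannot be told apart here, even though methoxy is the only one of the three that brings a hydrogen-bond acceptor. No supporting measurement is available to explain why the three compounds read alike.

From the compounds shown here alone, whether an amine or a carboxylic acid on this carbon would give a step beyond the scatter remains open. All three compounds are also weak enough that it is unclear whether this position would matter more in a stronger inhibitor built on a changed core.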